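Adding a Second Chloro to the Anilino Ring of Compound 1

A few compounds are considered here, and "the series" means these few. Any claim that something is new, unique, unknown or untested is made for them only; others in the source may bear on it.

Measured so far:
compound 1 `COc1cc(/C=C/C(=O)c2sc(Nc3ccc(Cl)cc3)nc2C)cc(OC)c1OC`: > 25000 nM
compound 2 `Cc1nc(Nc2cccc(Cl)c2)sc1C(=O)/C=C/c1ccccc1`: > 25000 nM
compound 3 `Cc1nc(Nc2ccccc2)sc1C(=O)/C=C/c1ccccc1`: > 25000 nM

Compound 1 `COc1cc(/C=C/C(=O)c2sc(Nc3ccc(Cl)cc3)nc2C)cc(OC)c1OC` is tested in a functional assay on Bel-7402 cells (Homo sapiens) for cytotoxicity, read by MTT assay; a lower number here means a stronger inhibitor, a higher number a weaker inhibitor. For compound 1 the value > 25000 nM is a limit of the assay, not a number. Compound 2 `Cc1nc(Nc2cccc(Cl)c2)sc1C(=O)/C=C/c1ccccc1` also gives only a limit, > 25000 nM. Compound 3 `Cc1nc(Nc2ccccc2)sc1C(=O)/C=C/c1ccccc1` also gives only a limit, > 25000 nM. All three values sit at the same limit (the limit of > 25000 nM in this assay, at which 3 of the 3 values shown sit), so compound 1 cannot be placed above or below the others.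

The unmeasured compound 4 `COc1cc(/C=C/C(=O)c2sc(Nc3ccc(Cl)c(Cl)c3)nc2C)cc(OC)c1OC` differs from compound 1 in one place: chloro in place of hydrogen on an aromatic carbon. Going by the values given here, the only measured step that touches the anilino ring is a step that the two limits leave unreadable from compound 2 to compound 3, and it is unreadable as well. Among the compounds with values here, there is thus no measured step that shows this kind of change altering the read-out, and no basis for expecting compound 4 to leave the limit.

Compound 4 is therefore expected to give 30000 nM, within 10000 nM to 100000 nM, most likely again only as a limit, and the estimated step that the limit leaves unreadable from compound 1 to compound 4 is expected to stay within the scatter.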

Compound 4, half-maximal inhibitory concentration: > 25000 nM
Compound 4: a limit, no number; the forecaster's own chance of this, stated with the estimate: 80%; the middle value does not contradict the limit.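

In this assay compound 4 gives > 25000 nM as a limit of the assay, not a number. No step can be read between compound 1 and compound 4, since both values are limits: the limit of > 25000 nM in this assay, at which 4 of the 4 values shown sit.

The compounds shown leave open whether the added chloro changes the read-out at all.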